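Capping the Hydroxy Group of Compound 2

This account rests on a few compounds, and the source may have more. Where it says the series, first, only, none or still open, it means among the compounds named here.

Going by the values given here, in a functional assay on PC-3 cells (Homo sapiens) for cytotoxicity, read by sulforhodamine B assay, with a stated time of 72 h (on this read-out lower numbers stand for stronger inhibition and higher numbers for weaker inhibition), compound 2 `COc1cc(/C=C/C(=O)/C=C(O)/C=C/c2ccc(OC(C)(C)C(=O)Nc3ccc(C#N)c(C(F)(F)F)c3)c(OC)c2)ccc1O` gives 48100 nM, the only true number among the three compounds measured so far. Compound 1 `COc1cc(/C=C/C(=O)/C=C(O)/C=C/c2ccc(OC(C)(C)C(=O)Nc3ccc([N+](=O)[O-])c(C(F)(F)F)c3)c(OC)c2)ccc1O` shows > 100000 nM, which is a limit of the assay and not a number. Compound 3 `COc1cc(/C=C/C(=O)/C=C(O)/C=C/c2ccc(OC(C)(C)C(=O)Nc3ccc(C)c(C(F)(F)F)c3)c(OC)c2)ccc1O` shows > 100000 nM, again a limit.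

Compound 4 `COc1ccc(/C=C/C(=O)/C=C(O)/C=C/c2ccc(OC(C)(C)C(=O)Nc3ccc(C#N)c(C(F)(F)F)c3)c(OC)c2)cc1OC` departs from compound 2 in one place: methyl in place of hydrogen on an oxygen on an aromatic ring. A methyl takes the place of hydrogen on an oxygen on an aromatic ring, turning 4-hydroxy-3-methoxyphenyl into 3,4-dimethoxyphenyl.

The measured steps concern a different change, the exchange of nitro, cyano and methyl on an aromatic carbon. They comprise an at least 2.0-fold lower number from compound 1 to compound 2 (0.31 log units; beyond the scatter) and an at least 2.0-fold higher number from compound 2 to compound 3 (0.31 log units; beyond the scatter), while a step that the two limits leave unreadable from compound 1 to compound 3. The readable two are only bounds, set by the limit of > 100000 nM in this assay, at which 2 of the 3 values shown sit. They show that this assay can respond to a single exchange, but neither gives a size or direction for the new change.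

Among the compounds with values here, no measured step touches that oxygen, so the expectation rests on compound 2 at 48100 nM. No step beyond the scatter is expected, and the estimate is a 1.2-fold lower number from compound 2 to compound 4 (0.08 log units; within the scatter). The expected value for compound 4 is 40000 nM, within an estimated range of 10000 nM to 100000 nM.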

Compound 4, half-maximal inhibitory concentration: > 100000 nM
Compound 4 was reported as a limit; the forecaster's own chance of this, stated with the estimate: 25%; at least 2.5-fold (0.39 log units) between middle value and limit.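

In this assay, going by these compounds alone, methyl in place of hydrogen on an oxygen on an aromatic ring gives an at least 2.0-fold higher number from compound 2 to compound 4 (0.31 log units; beyond the scatter), the first readable step at this place, whereas the earlier steps concerned only the exchange of nitro, cyano and methyl on an aromatic carbon. Among the compounds shown, the hydroxy group of the 4-hydroxy-3-methoxyphenyl unit and the cyano group thus both accompany the one true number: compound 2 carries both, and exchanging either one, as in compound 1, compound 3 and compound 4, leads to a limit rather than a number. The step is therefore a bound and gives no full size for the change, and its reading stops here: the limit of > 100000 nM in this assay, at which 3 of the 4 values shown sit.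

Going by these compounds, how far compound 4 lies from compound 2 stays unknown, as does whether the same methyl would matter in compound 1 or compound 3, which already stand at a limit. On these data alone, it also remains open how an ethoxy group, an amine or a carboxylic acid in place of the hydroxy group at this position would read in this assay.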